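The compounds below may be only part of what the source reports. "The series", "measured", "known", "first", "only" and "open" are said of these compounds alone.

Measured so far in a physicochemical assay for solubility, tested at 500 uM; a lower number here means a less soluble compound, a higher number a more soluble compound: compound 1 `COc1ccccc1-c1nc(C)c(COc2ccccc2C(=O)O)o1` with 402000 nM; compound 2 `COc1cccc(-c2nc(C)c(COc3ccccc3C(=O)O)o2)c1` with 264000 nM; compound 3 `COc1ccccc1-c1nc(C)c(COc2cccc(C(=O)O)c2)o1` with 423000 nM.

The three values lie close together, all within the usual scatter of one another. Compound 4 `COc1cccc(-c2nc(C)c(COc3cccc(C(=O)O)c3)o2)c1` has not yet been measured. It arises from compound 3 by 3-methoxyphenyl in place of 2-methoxyphenyl on an aromatic carbon. The same change turns compound 1 into compound 2, (3-methoxyphenyl in place of 2-methoxyphenyl on an aromatic carbon), and there it gave a 1.5-fold lower number from compound 1 to compound 2 (0.18 log units; within the scatter). The two places are described in the same words, so this is the same change, and it occurs twice among these compounds. How the core of compound 3 differs from the core of compound 1 is not broken down here. A step of similar size is expected, a 1.5-fold lower number from compound 3 to compound 4 (0.16 log units; within the scatter), because a 1.5-fold lower number from compound 1 to compound 2 (0.18 log units; within the scatter) stays within the scatter. Compound 4 is accordingly estimated at 290000 nM in this assay, with a likely range from 150000 nM to 500000 nM.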

Compound 4, solubility: 498000 nM
Estimate against measurement, compound 4: 1.7-fold (0.23 log units) below; the range from low to high includes it.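

In this assay, 3-methoxyphenyl in place of 2-methoxyphenyl gave a 1.2-fold higher number from compound 3 to compound 4 (0.07 log units; within the scatter) on the second core and a 1.5-fold lower number from compound 1 to compound 2 (0.18 log units; within the scatter) on the first. In neither core does the change stand out from repeat measurements, so the result shows only that carrying it across left no step beyond the scatter, and it does not show that the change has any real effect or that the two cores respond alike or differently. Nothing given here bears on the reason for these values.

On these data alone, all four compounds carry a carboxylic acid, so how this read-out would behave with an amide or an amine in its place remains open. Also open, as far as these compounds go, is whether the same holds with a longer chain in place of the methyl group on the shared core.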